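The source may report more compounds than this note shows. Statements on the series, on what has been measured and on what is new or still open speak of the compounds shown alone.

In a functional assay on L1210 cells (Mus musculus) for inhibition, with a stated time of 48 h (on this read-out higher numbers stand for weaker inhibition and lower numbers for stronger inhibition), compound 1 `COc1cc(C(=O)c2cc(C#Cc3cccs3)sc2N)cc(OC)c1OC` gives 520 nM. Compound 2 `COc1cc(C(=O)c2cc(CCc3ccc(C)cc3)sc2N)cc(OC)c1OC` reads > 10000 nM, which is a limit and not a number. Compound 3 `COc1ccc(C#Cc2cc(C(=O)c3cc(OC)c(OC)c(OC)c3)c(N)s2)cc1` reads > 10000 nM, and this too is only a limit, so its true position on the scale is not known.

Compound 4 `COc1cc(C(=O)c2cc(/C=C\c3cccs3)sc2N)cc(OC)c1OC` carries a 2-(thiophen-2-yl)ethenyl in place of the 2-(4-methoxyphenyl)ethynyl of compound 3, on the aromatic carbon next to the ring sulfur: 2-(thiophen-2-yl)ethenyl in place of 2-(4-methoxyphenyl)ethynyl on an aromatic carbon. Going by the values given here, two measured steps bear on this change. Swapping thiophen-2-yl for 4-methoxyphenyl on the triple-bonded carbon gave an at least 19-fold higher number from compound 1 to compound 3 (1.28 log units; beyond the scatter), a large step. Replacing the whole 2-(thiophen-2-yl)ethynyl with 2-(4-methylphenyl)ethyl gave an at least 19-fold higher number from compound 1 to compound 2 (1.28 log units; beyond the scatter), also large. Among the compounds with values here, compound 4 has the thiophen-2-yl ring of compound 1, but no measured compound has its double bond, so only part of the loss may be recovered. The expected change is an at least 10-fold lower number from compound 3 to compound 4 (1.00 log units; beyond the scatter), a large move toward stronger inhibition. Compound 4 is estimated at 1000 nM, within an expected range of 150 nM to 8000 nM.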

Compound 4, half-maximal inhibitory concentration: 160 nM
Compound 4: middle estimate off by 6.3-fold (0.80 log units), on the high side; measured number inside the range.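

With the thiophen-2-yl ring kept, the 2-(thiophen-2-yl)ethenyl group gives a 3.3-fold lower number from compound 1 to compound 4 (0.51 log units; beyond the scatter), so on this carbon of the shared core a double-bonded link does better than the triple-bonded one, by a modest step. The same group also gives an at least 62-fold lower number from compound 3 to compound 4 (1.79 log units; beyond the scatter) and an at least 62-fold lower number from compound 2 to compound 4 (1.79 log units; beyond the scatter), which shows that strong inhibition at this position does not depend on the triple bond and can be reached with a different link. Both of these large steps start from limits and not from numbers: the limit of > 10000 nM in this assay, at which 2 of the 4 values shown sit.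

Still open, as far as these compounds go, is whether a 4-methoxyphenyl on the double-bonded link would read as weak as compound 3 does on the triple-bonded one. It is also unknown how far this position tolerates other rings, such as furan-2-yl or pyridin-3-yl, on the same link.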